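Benzyl in place of phenyl on the ring amine of compound 1

The source may report more compounds than this note shows. Statements on the series, on what has been measured and on what is new or still open speak of the compounds shown alone.

Compounds measured so far in an ADME assay on the whole organism (Rattus norvegicus) for pharmacokinetics, read by LC-MS; a lower number here means that more of the compound stays in the plasma, a higher number that more of the compound sits outside the plasma:
- compound 1, `Cc1ccc(-c2c3c(nc(C)c2[C@H](OC(C)(C)C)C(=O)O)CCN(c2ccccc2)C3)cc1`: 3 L/kg
- compound 2, `Cc1nc2c(c(-c3cc(F)c4c(c3C)CCCO4)c1[C@H](OC(C)(C)C)C(=O)O)CN(CCCc1ccc(F)cc1)CC2`: 1 L/kg
- compound 3, `Cc1ccc(-c2c3c(nc(C)c2C(OC(C)(C)C)C(=O)O)CCN(CCCC2CCCC2)C3)cc1`: 66 L/kg

Among these three numbers compound 1 sits second highest. Compound 2, its nearest neighbour, gives a number that is beyond the scatter on the lower side, and compound 3 gives a far higher number, also well beyond the scatter. Compounds 2 and 3 both carry a flexible chain on the ring nitrogen that in compound 1 carries a phenyl, yet they land on opposite sides of compound 1, so the three values together do not fix a single direction for changes at that nitrogen.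

Compound 4, `Cc1ccc(-c2c3c(nc(C)c2[C@H](OC(C)(C)C)C(=O)O)CCN(Cc2ccccc2)C3)cc1`, has not yet been measured in this assay. It differs from compound 1 in one place: benzyl in place of phenyl on an amine nitrogen in a ring. Nothing else in the core changes. Because compound 3 reaches 66 L/kg with a chain on this nitrogen while compound 1 stays at 3 L/kg, a modest rise is expected for compound 4 rather than a fall, though compound 2 with 1 L/kg shows the opposite is possible. The estimated step of a 2.7-fold higher number from compound 1 to compound 4 (0.43 log units; beyond the scatter) is expected to exceed the scatter only slightly. Compound 4 is therefore estimated at 8 L/kg, within 2.5 L/kg to 30 L/kg.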

Compound 4, volume of distribution at steady state: 7 L/kg
Beside the measured number, compound 4's estimate is 1.1-fold (0.06 log units) above it, and the stated range covers the measured number.
By their numbers in this assay, from the lowest: compound 2; then compound 1; then compound 4; then compound 3.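

Among these compounds, compound 1 and compound 4 differ in one place only, so this pair isolates the group on the amine nitrogen in the ring, which the earlier compounds could not do because each differs from the others in more than one place. In this assay, benzyl in place of phenyl gives a 2.3-fold higher number from compound 1 to compound 4 (0.37 log units; beyond the scatter), a modest step, yet one showing that this small change on an otherwise unchanged core is enough to shift the reading, with more of compound 4 sitting outside the plasma. The numbers show the size and direction of this single step, but no measurement shown explains why it happens.

As far as these compounds go, what a phenethyl group would give at this nitrogen remains open, so a single step cannot tell whether the number in this assay would keep rising as the link between the nitrogen and the aromatic ring grows longer. Also open, from the compounds shown here alone, is how a benzyl carrying a hydroxyl or an amine on its aromatic ring would read, and whether the same step would appear on a different core.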